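Series notes: N-substituent variation on the shared core

This account rests on a few compounds, and the source may have more. Where it says the series, first, only, none or still open, it means among the compounds named here.

Measured so far in an assay on cell membranes for displacement of a labelled ligand from Cholecystokinin receptor type A (Rattus norvegicus), read by CCK-8 assay, with a stated time of 2 h; on this read-out higher numbers stand for weaker inhibition and lower numbers for stronger inhibition:
compound 1 `CC(C)N1C(=O)C=C(Cl)C1(O)c1ccccc1` gives 200 nM
compound 2 `CC(C)N1C(=O)C=C(Cl)C1(O)c1ccc(Cl)cc1` gives 300 nM
compound 3 `CC(C)CN1C(=O)C=C(Cl)C1(O)c1ccccc1` gives 20 nM

Compound 2 stands at the high end of the three numbers; compound 1 sits within the usual scatter of it (a 1.5-fold higher number from compound 1 to compound 2 (0.18 log units; within the scatter)), whereas compound 3 lies well beyond the scatter on the lower side. Compound 4 `CCCCCCN1C(=O)C=C(Cl)C1(O)c1ccc(Cl)cc1` is not yet measured. It differs from compound 2 in one place: hexyl in place of isopropyl on an amide-type nitrogen in a ring.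

Going by the values given here, the only measured step that bears on a change at this nitrogen is a 10-fold lower number from compound 1 to compound 3 (1.00 log units; beyond the scatter), where a chain one carbon longer brought a clearly lower number. Among the compounds with values here, no measured step covers a hexyl chain, so the further extension is an extrapolation; the aromatic chloro present in compound 2 and compound 4 alike moved the number only within the scatter (a 1.5-fold higher number from compound 1 to compound 2 (0.18 log units; within the scatter)). On this basis a lower number than compound 2 is expected in this assay, of a size around a 5.0-fold lower number from compound 2 to compound 4 (0.70 log units; beyond the scatter). Compound 4 is therefore estimated at 60 nM, with a range from 15 nM to 250 nM.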

Compound 4, half-maximal inhibitory concentration: 3600 nM
Estimate against measurement, compound 4: 60-fold (1.78 log units) below; the measured number lies above the stated range.
By their numbers in this assay, from the lowest: compound 3; then compounds 1 and 2 (each within the scatter of the next); then compound 4.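

At the amide-type nitrogen in a ring, in this assay, the step to hexyl gives a 12-fold higher number from compound 2 to compound 4 (1.08 log units; beyond the scatter), so the number at this position does not fall steadily as the alkyl group grows. Its direction is opposite to that of a 10-fold lower number from compound 1 to compound 3 (1.00 log units; beyond the scatter), although the isobutyl step lacks the aromatic chloro that the hexyl step carries, so the two steps are not a strict like-for-like pair. No measurement at hand accounts for this reversal.

The compounds shown leave open where between isobutyl and hexyl the number turns upward, which butyl or pentyl at this nitrogen could help to place. They also leave open whether hexyl behaves the same way without the aromatic chloro, and whether a chain ending in an amine or a carboxylic acid would follow the hexyl result.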